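The source may hold more compounds than are shown below. What is called first, only, known or untested is meant among the compounds shown, and "the series" means these compounds.

Measured compounds:
Compound 1, `CN(C)CC1CCC/C(=C\c2ccc(OC(=O)/C=C/c3ccccc3)cc2)C1=O`, gives 4020 nM in a functional assay on P388 cells (Mus musculus); on this read-out higher numbers stand for weaker inhibition and lower numbers for stronger inhibition.
Compound 2, `CN(C)CC1CCC/C(=C\c2ccc(OC(=O)/C=C/c3ccc(Br)cc3)cc2)C1=O`, gives 4030 nM.
Compound 3, `CN(C)CC1CCC/C(=C\c2ccc(OC(=O)/C=C/c3ccc(Cl)c(Cl)c3)cc2)C1=O`, gives 4180 nM.

Compound 3 stands alongside the other two: the step of a 1.0-fold higher number from compound 1 to compound 3 (0.02 log units; within the scatter) and the step of a 1.0-fold higher number from compound 2 to compound 3 (0.02 log units; within the scatter) both lie within the scatter, as does a 1.0-fold higher number from compound 1 to compound 2 (0.00 log units; within the scatter). Compound 4, `CN(C)CC1CCC/C(=C\c2ccc(OC(=O)c3ccc(Cl)cc3)cc2)C1=O`, differs from compound 3 by 4-chlorophenyl in place of 2-(3,4-dichlorophenyl)ethenyl on a carbonyl carbon. Going by the values given here, each measured step only swapped substituents on the aromatic ring of the cinnamate, and none moved the number beyond the scatter; no measured step removes the ethenyl bridge, so the data give little guidance there. Compound 4 is therefore expected to show no change beyond the scatter, a 1.0-fold higher number from compound 3 to compound 4 (0.00 log units; within the scatter), with a wide margin, giving an estimated 4200 nM, ranging from 1800 nM to 10000 nM.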

Compound 4, half-maximal inhibitory concentration: 425 nM
For compound 4 the middle estimate is 9.9-fold (0.99 log units) above the measured one; the whole stated range lies above it.
By their numbers in this assay, from the lowest: compound 4; then compounds 1, 2 and 3 (each within the scatter of the next).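

Putting 4-chlorophenyl on the carbonyl carbon in place of the ethenyl-bearing groups gives a 9.8-fold lower number from compound 3 to compound 4 (0.99 log units; beyond the scatter) in this assay and likewise a 9.5-fold lower number from compound 2 to compound 4 (0.98 log units; beyond the scatter) and a 9.5-fold lower number from compound 1 to compound 4 (0.98 log units; beyond the scatter) in each case. Unlike the swaps on the aromatic ring of the cinnamate, this change on the carbonyl carbon moves the number beyond the scatter. Nothing available explains this result.

The compounds shown leave open whether the lost ethenyl bridge or the ring substitution carries the step, as compound 4 differs in both. Going by these compounds, how a plain phenyl or a 4-methoxyphenyl on the carbonyl carbon would read also stays open.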